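The source may report more compounds than this note shows. Statements on the series, on what has been measured and on what is new or still open speak of the compounds shown alone.

Measured in a functional assay on MCF7 cells (Homo sapiens) for inhibition; a higher number here means a weaker inhibitor of growth, a lower number a stronger inhibitor of growth:
compound 1, `C=CCOC(=O)c1ccsc1NC(=O)[C@@H]1CCCN1`, gives 96.6 ug/mL;
compound 2, `O=C(OCC(F)(F)F)c1ccsc1NC(=O)[C@@H]1CCCN1`, gives 89.7 ug/mL;
compound 3, `COC(=O)c1ccsc1NC(=O)[C@H]1CCCN1`, gives 179 ug/mL.

Compound 2 holds the lowest of the three numbers, yet its gaps to compound 1 and to compound 3 both lie within the scatter, so no order among the three can be drawn. Compound 4, `O=C(Oc1ccccc1)c1ccsc1NC(=O)[C@@H]1CCCN1`, differs from compound 2 by phenyl in place of 2,2,2-trifluoroethyl on an oxygen next to a carbonyl group. Within the data shown here, the only measured step on the oxygen next to a carbonyl group is a 1.1-fold lower number from compound 1 to compound 2 (0.03 log units; within the scatter), which moved nothing beyond the scatter. Among the measured compounds shown here, no measured step exchanges a saturated chain for a six-membered aromatic ring, so that step gives only weak guidance, and no change beyond the scatter is expected in this assay. Compound 4 is therefore expected to give about 100 ug/mL, within 50 ug/mL to 200 ug/mL, an expected step of a 1.1-fold higher number from compound 2 to compound 4 (0.05 log units; within the scatter).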

Compound 4, concentration for 50% growth inhibition: > 250 ug/mL
Compound 4 ended at the assay's limit; the forecaster's own chance of this, stated with the estimate: 10%; middle value at least 2.5-fold (0.39 log units) from the limit.
By their numbers in this assay, from the lowest: compounds 2, 1 and 3 (each within the scatter of the next). At a limit, above all of these: compound 4.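

Compound 4 stands at a limit of this assay, not at a number: the limit of > 250 ug/mL in this assay, at which 1 of the 4 values shown sits.

Even so, phenyl on the oxygen next to a carbonyl group is the first change there to pass the scatter, with an at least 2.7-fold higher number from compound 2 to compound 4 (0.44 log units; beyond the scatter) and an at least 2.5-fold higher number from compound 1 to compound 4 (0.41 log units; beyond the scatter). This position, where allyl and 2,2,2-trifluoroethyl gave values within the scatter of each other, therefore does respond to the group it carries, and phenyl gives weaker growth inhibition.

The compounds shown leave open whether benzyl or a longer chain on that oxygen would behave like phenyl or like allyl. From the compounds shown here alone, how large the step to phenyl really is also stays open.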